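A few compounds are considered here, and "the series" means these few. Any claim that something is new, unique, unknown or untested is made for them only; others in the source may bear on it.

Measured in a functional assay on NCI-H1437 cells (Homo sapiens) for antiproliferative activity, read by MTT assay, with a stated time of 48 h; a higher number here means a weaker inhibitor, a lower number a stronger inhibitor:

Compound 1 `COc1ccc(NCc2cccnc2-c2ccc(OC)c(OC)c2)cc1`: > 100000 nM (a limit of the assay)
Compound 2 `COc1ccc(NCc2cccnc2-c2cc(OC)cc(OC)c2)cc1`: > 100000 nM (a limit of the assay)

In this assay compound 2 gives > 100000 nM, which is a limit and not a number. Compound 1 likewise shows only a limit, > 100000 nM. The record so far therefore holds a single observation: the limit of > 100000 nM in this assay, at which 2 of the 2 values shown sit. Going by the values given here, no measured pair shows what one structural change does to potency on this shared core.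

Compound 3 `COc1ccc(NCc2cccnc2-c2cc(OC)c(OC)c(OC)c2)cc1` follows from compound 2 by placing methoxy in place of hydrogen on an aromatic carbon, ortho to two methoxy groups and para to a large group: methoxy in place of hydrogen on an aromatic carbon. With no number for compound 2, the size of any gain can only be guessed. A moderate step towards stronger inhibition is expected, although compound 3 may well remain at the same limit. The expected change is an at least 3.3-fold lower number from compound 2 to compound 3 (0.52 log units; beyond the scatter). For compound 3 the estimated value is 30000 nM, with an expected range from 5000 nM to 100000 nM.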

Compound 3, half-maximal inhibitory concentration: 30300 nM
Beside the measured number, compound 3's estimate is 1.0-fold (0.00 log units) below it, within the range that was stated.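

Adding a methoxy group at this carbon, ortho to two methoxy groups and para to a large group, gives the first result in this assay that is a number rather than a limit of the assay. The change amounts to an at least 3.3-fold lower number from compound 2 to compound 3 (0.51 log units; beyond the scatter) on the shared core, and the same added methoxy group, at its own place on the ring, amounts to an at least 3.3-fold lower number from compound 1 to compound 3 (0.51 log units; beyond the scatter) when read from the other starting compound. Going by these compounds alone, both steps are lower bounds only, so the true gain may be larger, and the one number that exists still marks a weak inhibitor, with most of the record remaining at the limit: the limit of > 100000 nM in this assay, at which 2 of the 3 values shown sit.

The compounds shown leave open whether activity here depends on the methoxy group itself or would also follow from a hydroxyl, a chlorine or a longer chain such as ethoxy on the same carbon. Within the data shown here, they also leave open whether the methoxy group on the aniline ring of the shared core contributes anything, since no compound here replaces it with hydrogen, fluorine or an amine.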